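The compounds below may be only part of what the source reports. "The series", "measured", "known", "first", "only" and "open" are said of these compounds alone.

Series notes. Compound 1 `Cc1ccc2c(=O)c(CSC(=S)N3CCCCC3)coc2c1` has been measured in a functional assay on HeLa cells (Homo sapiens) for antiproliferative activity, read by MTT assay, with a stated time of 72 h (on this read-out lower numbers stand for stronger inhibition and higher numbers for weaker inhibition), and gives only a limit, > 25000 nM, not a number. It therefore stands at the limit of > 25000 nM in this assay, at which 2 of the 3 values shown sit. Compound 2 `COc1ccc2occ(CSC(=S)N(C(C)C)C(C)C)c(=O)c2c1` gives 5400 nM in this assay. Compound 3 `COc1ccc2oc(CSC(=S)N3CCOCC3)cc(=O)c2c1` likewise returns a limit in this assay, > 25000 nM. Compound 4 `Cc1ccc2c(=O)c(CSC(=S)N3CCOCC3)coc2c1` is not yet measured and differs from compound 1 by morpholin-4-yl in place of piperidin-1-yl on a thiocarbonyl carbon. The same morpholin-4-yl group is present in compound 3, which also sits at a limit in this assay. Among the compounds with values here, only compound 2, carrying a different amine, gives a number, so no measured step within the ring-amine family is available. The expected step is a step that the limit leaves unreadable from compound 1 to compound 4, none beyond the scatter, with a limit again the most likely outcome. Compound 4 is expected at 30000 nM, within 10000 nM to 100000 nM.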

Compound 4, half-maximal inhibitory concentration: 6100 nM
Estimate against measurement, compound 4: 4.9-fold (0.69 log units) above, outside the stated range (below it).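

Morpholin-4-yl in place of piperidin-1-yl on a thiocarbonyl carbon gives, in this assay, an at least 4.0-fold lower number from compound 1 to compound 4 (0.61 log units; beyond the scatter) on the shared core. Compound 1 gives > 25000 nM here, a limit and not a number, and the step is therefore a bound only. Within the data shown here, a ring amine at this place can thus give a measurable value, which no earlier compound showed.

Going by these compounds, how far the two compounds truly lie apart stays open. Also open, on these data alone, is whether thiomorpholin-4-yl or piperazin-1-yl on the same thiocarbonyl carbon would move the value further.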